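Shrinking a benzyl group to a methyl

This account rests on a few compounds, and the source may have more. Where it says the series, first, only, none or still open, it means among the compounds named here.

Compound 1 `COc1ccc(O)c(C(=O)Nc2ccc(C#N)cc2)c1`: > 10000 nM (a limit of the assay, not a number)
Compound 2 `N#Cc1ccc(NC(=O)c2cc(-c3ccccc3)ccc2O)cc1`: 1300 nM
Compound 3 `N#Cc1ccc(NC(=O)c2cc(Cc3ccccc3)ccc2O)cc1`: 1930 nM

All three were tested in a functional assay on KG-1 cells (Homo sapiens) for cytotoxicity, read by luminescence and CellTiter-Glo, with a stated time of 3 days; on this read-out lower numbers stand for stronger inhibition and higher numbers for weaker inhibition. Among the compounds with values here, compound 3 stands level with compound 2, the only other compound with a true number. The gap is a 1.5-fold higher number from compound 2 to compound 3 (0.17 log units; within the scatter). Compound 1 gives only a limit.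

Compound 4 `Cc1ccc(O)c(C(=O)Nc2ccc(C#N)cc2)c1` differs from compound 3 in one place: hydrogen in place of phenyl on a saturated chain carbon bound to an aromatic carbon. This puts hydrogen in place of phenyl on a saturated chain carbon bound to an aromatic carbon, so benzyl becomes methyl.

Within the data shown here, two measured steps bear on this change. Replacing methoxy with a ring-bearing group gave an at least 7.6-fold lower number from compound 1 to compound 2 (0.88 log units; beyond the scatter) and an at least 5.1-fold lower number from compound 1 to compound 3 (0.71 log units; beyond the scatter). Both sizes are minimums, since they start from a limit. Methyl, like the methoxy of compound 1, carries no ring, although no measured step covers methyl itself. Losing the ring from compound 3 should therefore undo much of an at least 5.1-fold lower number from compound 1 to compound 3 (0.71 log units; beyond the scatter), so a clearly higher number is expected. The expected step is a 4.1-fold higher number from compound 3 to compound 4 (0.62 log units; beyond the scatter). For compound 4 the estimated value is 8000 nM, with an expected range from 3000 nM to 20000 nM.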

Compound 4, half-maximal inhibitory concentration: 3370 nM
Estimate against measurement, compound 4: 2.4-fold (0.38 log units) above; measured number inside the range.
By their numbers in this assay, from the lowest: compounds 2, 3 and 4 (each within the scatter of the next, the first and the last beyond it). At a limit, above all of these: compound 1.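

Cutting benzyl back to methyl costs little that can be detected in this assay, with a 1.7-fold higher number from compound 3 to compound 4 (0.24 log units; within the scatter), yet compound 2, which carries its phenyl directly on the aromatic carbon, is separated from compound 4 by a 2.6-fold higher number from compound 2 to compound 4 (0.41 log units; beyond the scatter), so two steps that each look small can add up to a real gap. The result also shows that a ring is not required for a measurable number at this place, since methyl alone gives an at least 2.9-fold lower number from compound 1 to compound 4 (0.47 log units; beyond the scatter). That step is only a minimum because compound 1 gives a limit and not a number: the limit of > 10000 nM in this assay, at which 1 of the 4 values shown sits.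

On these data alone, what remains open is which feature of the group at this place sets the number, since methoxy, methyl, benzyl and phenyl differ in more than one way and four compounds cannot separate those differences. It is also unclear how a longer chain such as propyl, an amine or a carboxylic acid would read here, or whether plain hydrogen on the aromatic carbon would fall closer to compound 1 or to compound 4.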